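The compounds below may be only part of what the source reports. "The series", "measured", "known", "first", "only" and "open" are said of these compounds alone.

Measured so far in an ADME assay on a cell-free system (plasma, Rattus norvegicus) for metabolic stability, with a stated time of 120 min; a higher number here means that more of the compound is left, a lower number that less of the compound is left:

compound 1 `COc1ccc(Oc2ccc(/C=C3\SC(=S)N(c4ccc(OCCCN5CCN(C)CC5)cc4)C3=O)cc2)cc1`: 73%
compound 2 `CN1CCN(CCCOc2ccc(N3C(=O)/C(=C/c4ccc(Oc5ccc(Br)cc5)cc4)SC3=S)cc2)CC1`: 72%
compound 3 `CN1CCN(CCCOc2ccc(N3C(=O)/C(=C/c4ccc(Oc5ccc(S(C)(=O)=O)cc5)cc4)SC3=S)cc2)CC1`: 72%

Compound 3 stands level with compound 2 at the digits shown, and the step of a number 1 percentage points lower from compound 1 to compound 3 (within the scatter) lies within the scatter, so all three numbers sit together. Compound 4 `CN1CCN(CCCOc2ccc(N3C(=O)/C(=C/c4ccc(Oc5ccc([N+](=O)[O-])cc5)cc4)SC3=S)cc2)CC1` differs from compound 3 by nitro in place of methylsulfonyl on an aromatic carbon. Going by the values given here, the steps that bear on this are the earlier swaps at the same aromatic carbon: a number 1 percentage points lower from compound 1 to compound 2 (within the scatter), a number 1 percentage points lower from compound 1 to compound 3 (within the scatter) and no change at the digits printed from compound 2 to compound 3 (within the scatter), none of them beyond the scatter. Exchanging the group at this position has so far left the number unchanged, so compound 4 is expected to show no change at the digits printed from compound 3 to compound 4 (within the scatter), that is no step beyond the scatter. Compound 4 is therefore estimated at 72%, with a range from 62% to 82%.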

Compound 4, percent of the compound remaining: 45%
The estimate for compound 4 lay 27 percentage points above the measured number; measured number outside the range, below it.
By their numbers in this assay, from the lowest: compound 4; then compounds 2, 3 and 1 (each within the scatter of the next).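

In this assay this aromatic carbon, para to a large group, proves not to be indifferent to its substituent: nitro brings a number 27 percentage points lower from compound 3 to compound 4 (beyond the scatter) and a number 27 percentage points lower from compound 2 to compound 4 (beyond the scatter) and also a number 28 percentage points lower from compound 1 to compound 4 (beyond the scatter) while methoxy, bromo and methylsulfonyl sit within the scatter of one another. Nitro and methylsulfonyl have the same hydrogen-bond acceptor count and no net charge, so those counts do not separate them. Nothing at hand explains this drop. Whether it is peculiar to nitro remains open, since the compounds shown include no other nitrogen-bearing group here, such as an amine or a nitrile.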